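The compounds below may be only part of what the source reports. "The series", "measured", "known", "first", "only" and "open" are said of these compounds alone.

Measured so far in a functional assay on PC-9 cells (Homo sapiens) for inhibition, read by MTT assay, with a stated time of 48 h, tested at 10 uM; on this read-out lower numbers stand for less inhibition and higher numbers for more inhibition at the one concentration tested (going by the name of the read-out):
- compound 1 `CCc1ccc(Nc2cc(NC(=O)Nc3cc(OC)cc(OC)c3)ncn2)cc1`: 78%
- compound 2 `COc1cc(NC(=O)Nc2cc(Nc3cc(C(F)(F)F)ccc3OC)ncn2)cc(OC)c1`: 81.1%
- compound 3 `COc1ccc(C(F)(F)F)cc1Nc1cc(NC(=O)Nc2c(Cl)cccc2Cl)ncn1`: 89%

Compound 1 gives the lowest of the three numbers in this assay. Its nearest neighbour is compound 2, which lies within the scatter of it; only compound 3 sits beyond the scatter above it. Among the measured compounds shown here, the one step that can be read as a single change, a number 7.9 percentage points higher from compound 2 to compound 3 (within the scatter), concerns a group on an amide-type nitrogen and stays within the scatter.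

Compound 4 `COc1cc(NC(=O)Nc2cc(Nc3ccc(OC)c(C)c3)ncn2)cc(OC)c1` is not yet measured. Against compound 1 the change is 4-methoxy-3-methylphenyl in place of 4-ethylphenyl on a nitrogen on an aromatic ring. For the measured compounds named here, no measured step touches this place. Compound 2 differs from compound 1 at the same place, and its value and that of compound 1 lie within the scatter of each other; that is all the series shows. Going by the values given here, the single measured step, being within the scatter, gives no reason to expect a shift in either direction. For compound 4 a number close to compound 1 is therefore expected, a number 2 percentage points higher from compound 1 to compound 4 (within the scatter), with the estimate 80% spanning 66% to 92%.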

Compound 4, a percentage reported as inhibition, at one concentration (the size of the read-out at that concentration, not a potency): 62%
Estimate against measurement, compound 4: 18 percentage points above, and the stated range ends above it.
By their numbers in this assay, from the lowest: compound 4; then compounds 1, 2 and 3 (each within the scatter of the next, the first and the last beyond it).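

In this assay, the group on a nitrogen on an aromatic ring now shows a change beyond the scatter: with 4-methoxy-3-methylphenyl in place of 4-ethylphenyl, the step reads a number 16 percentage points lower from compound 1 to compound 4 (beyond the scatter). Compound 2, which also carries a methoxy group on this ring, gives 81.1%, while compound 4 gives 62%, so a methoxy group as such does not settle the number at this place. Nothing at hand accounts for the lower number of compound 4.

It stays open whether that lower number goes with the methyl or with the methoxy part of the new group, as no compound shown has 4-methoxyphenyl or 3-methylphenyl at this place. Also open, as far as these compounds go, is how this ring behaves with an amine or a carboxylic acid on it.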